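Cytotoxicity limits across a chlorobenzimidazole series; next substituent step

The source may report more compounds than this note shows. Statements on the series, on what has been measured and on what is new or still open speak of the compounds shown alone.

Measured compounds in an ADME assay on HEp-2 cells (Homo sapiens) for cytotoxicity, with a stated time of 4 days; on this read-out lower numbers stand for higher toxicity in this test and higher numbers for lower toxicity in this test:
- compound 1, `CS(=O)(=O)CCCn1c(Cn2cc(S(C)(=O)=O)c3ccccc32)nc2cc(Cl)ccc21`: > 100000 nM
- compound 2, `CS(=O)(=O)CCCn1c(Cn2cc(S(=O)(=O)C3CC3)c3ccccc32)nc2cc(Cl)ccc21`: > 100000 nM
- compound 3, `CS(=O)(=O)c1nn(Cc2nc3cc(Cl)ccc3n2CCCCO)c2cnccc12`: > 100000 nM

Each of these values is a limit of this assay, not a number. In this assay compound 1 reaches only the limit > 100000 nM. For compound 2 the same limit > 100000 nM is recorded. For compound 3 again only the limit > 100000 nM is known. Among the measured compounds shown here, the single step between neighbours, a step that the two limits leave unreadable from compound 1 to compound 2, cannot be read in size or direction. Compound 3 therefore stands where every measured compound stands, at the limit of > 100000 nM in this assay, at which 3 of the 3 values shown sit.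

Compound 4, `COCCOCCn1c(Cn2nc(S(C)(=O)=O)c3ccncc32)nc2cc(Cl)ccc21`, has not yet been measured in this assay. It differs from compound 3 by 2-methoxyethoxy in place of 2-hydroxyethyl on a saturated chain carbon, two bonds along the chain from an aromatic nitrogen. For the measured compounds named here, no measured step bears on this change, and the one measured step is unreadable. Nothing in the recorded values sets any compound apart from the others.

On this basis compound 4 is expected to sit at the limit of this assay as well, giving an estimate of 100000 nM with a range from 50000 nM to 200000 nM. The step this implies, a number no higher from compound 3 to compound 4 (the limit leaves the size open), is expected to be none beyond the scatter.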

Compound 4, half-maximal cytotoxic concentration: > 100000 nM
Compound 4 gave a limit, no number; the forecaster's own chance of this, stated with the estimate: 85%; the middle value sits exactly at the limit.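

Compound 3 and compound 4 both give limits, not numbers, in this assay, so the step between them cannot be read. The series stays at one place: the limit of > 100000 nM in this assay, at which 4 of the 4 values shown sit.

The compounds shown leave open at what concentration any of them would turn toxic in this assay, and whether 2-methoxyethoxy in place of 2-hydroxyethyl changes that concentration.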